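The compounds below may be only part of what the source reports. "The series", "measured", "known", "first", "only" and "open" are said of these compounds alone.

Two measured compounds and one still to be measured make up the set. Compound 1 `Cc1ccc2c(=S)cc(-c3ccccc3)oc2c1` has been run in an in vitro assay on BTI-TN-5B1-4 cells for inhibition of Amine oxidase [flavin-containing] B (Homo sapiens), tested at 100 uM; a lower number here means less inhibition, a higher number more inhibition at the concentration tested (going by the name of the read-out); in it compound 1 gives 40%. Compound 2 `Fc1ccc(-c2cc(=S)c3ccccc3o2)cc1` is in the same assay reported as "not active" (no number reported), with no number behind that word, so compound 2 stands without a figure in this assay. Among the measured compounds shown here, compound 1 and compound 2 differ in two places, so no single step connects them; only the two readings themselves can be set side by side. Compound 3 `Cc1ccc2c(=S)cc(-c3ccc(F)cc3)oc2c1` is the member not yet measured. It arises from compound 2 by methyl in place of hydrogen on an aromatic carbon. For the measured compounds named here, no step between measured compounds covers this change. What can be expected for compound 3 in this assay rests on compound 1, which carries the same methyl and gives 40%, and on compound 2, which shares the rest of the structure and gives "not active" (no number reported). A rise beyond the scatter relative to compound 2 is plausible but not assured, and a reading that again carries no number cannot be ruled out. For compound 3 the expected inhibition in this assay is 20%, estimated to lie between 0% and 45%.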

Compound 3, a percentage reported as inhibition, at one concentration (the size of the read-out at that concentration, not a potency): 40%
Estimate against measurement, compound 3: 20 percentage points below; low and high end bracket the measured number.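

In this assay, introducing the fluoro gives no change at the digits printed from compound 1 to compound 3 (within the scatter), so with the methyl in place this replacement leaves no mark on the reading. Among the compounds shown here, compound 2, which lacks the methyl, is reported as "not active" (no number reported), while compound 3 gives 40%; the fluoro therefore does not rule out a numeric reading, and a number appears in the one fluoro compound with the methyl on the ring fused into the shared core. The step from compound 2 to compound 3 cannot be read, as compound 2 has no number, so the size of the methyl change stays unknown, and nothing measured here speaks to why these readings fall as they do.

Open, on these data alone, is whether the numeric reading depends on methyl specifically or would also appear with an ethyl group, a methoxy group or an amine at the same aromatic carbon. Also open, as far as these compounds go, is whether chlorine or a carboxylic acid in place of the fluoro would likewise leave the reading within the scatter of compound 1, and how any of these readings at a single concentration would translate into potency.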